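Nitro to Bromo: What Size of Step to Expect

The source may hold more compounds than are shown below. What is called first, only, known or untested is meant among the compounds shown, and "the series" means these compounds.

In a functional assay on NRK-49F cells (Rattus norvegicus) for cytotoxicity, read by MTT assay, with a stated time of 24 h (on this read-out lower numbers stand for stronger inhibition and higher numbers for weaker inhibition), compound 1 (`C/C(=N\NC(=O)/C(C#N)=C/c1ccccc1)c1c(O)c2ccc(O)cc2oc1=O`) gives 55500 nM and compound 2 (`C/C(=N\NC(=O)/C(C#N)=C/c1cccc([N+](=O)[O-])c1)c1c(O)c2ccc(O)cc2oc1=O`) gives 46500 nM, so compound 2 stands level with compound 1 within the scatter. Compound 3 (`C/C(=N\NC(=O)/C(C#N)=C/c1cccc(Br)c1)c1c(O)c2ccc(O)cc2oc1=O`) carries bromo in place of nitro on an aromatic carbon. Among the compounds with values here, no measured compound carries bromo. Within the data shown here, the only guide is a 1.2-fold lower number from compound 1 to compound 2 (0.08 log units; within the scatter), a nitro-for-hydrogen step within the scatter, so no step beyond the scatter is expected in this assay. The expected change is a 1.1-fold lower number from compound 2 to compound 3 (0.04 log units; within the scatter). Compound 3 is expected at 42000 nM, with an estimated range of 20000 nM to 85000 nM.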

Compound 3, half-maximal inhibitory concentration: 59400 nM
Beside the measured number, compound 3's estimate is 1.4-fold (0.15 log units) below it; the range from low to high includes it.
By their numbers in this assay, from the lowest: compounds 2, 1 and 3 (each within the scatter of the next).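

In this assay bromo in place of nitro gives a 1.3-fold higher number from compound 2 to compound 3 (0.11 log units; within the scatter) and bromo in place of hydrogen gives a 1.1-fold higher number from compound 1 to compound 3 (0.03 log units; within the scatter) on the same aromatic carbon. Hydrogen, a nitro group of three heavy atoms and a single bromine atom therefore all read alike at this position, with no step yet beyond the scatter. No evidence is available to explain these level numbers.

On these data alone, whether an amine or a carboxylic acid on this carbon would move the number beyond the scatter stays open. So does whether nitro or bromo would behave the same elsewhere on this ring.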